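Swapping the amide aryl group on a phthalimide-bearing benzamide scaffold

The source may report more compounds than this note shows. Statements on the series, on what has been measured and on what is new or still open speak of the compounds shown alone.

Among the compounds with values here, the three compounds measured so far share a core in which a phthalimide is linked through a methylene to an aniline that carries an amide. Compound 1 `O=C(Nc1cccc(F)c1CN1C(=O)c2ccccc2C1=O)c1ccccn1` pairs a fluoro substituent with a pyridine-derived amide, compound 2 `COc1ccccc1C(=O)Nc1ccc(Cl)cc1CN1C(=O)c2ccccc2C1=O` a chloro substituent with a 2-methoxyphenyl amide, and compound 3 `CCOc1cccc2c1C(=O)N(Cc1cc(Cl)ccc1NC(=O)c1ccccn1)C2=O` a chloro substituent with a pyridine-derived amide on a phthalimide that carries an ethoxy group. In an assay on CHO cells for positive allosteric modulation of metabotropic glutamate receptor 5 (Homo sapiens), read by FLIPR (on this read-out higher numbers stand for an effect only at larger amounts of compound and lower numbers for an effect already at smaller amounts), compound 3 gives 280 nM. For compound 1 this assay reports only a limit, > 100000 nM. For compound 2 the result is likewise only a limit, > 100000 nM, so compound 2 stands at the limit of > 100000 nM in this assay, at which 2 of the 3 values shown sit, rather than at a number. Compound 4 `O=C(Nc1ccc(Cl)cc1CN1C(=O)c2ccccc2C1=O)c1cccnn1` keeps the chloro substituent and the plain phthalimide of compound 2 and changes only the amide: pyridazin-3-yl in place of 2-methoxyphenyl on a carbonyl carbon. Within the data shown here, no measured pair isolates this change, so the expected step of an at least 5.0-fold lower number from compound 2 to compound 4 (0.69 log units; beyond the scatter) is uncertain, though a move toward an effect at smaller amounts is expected. Compound 4 is therefore estimated at 20000 nM, within a range from 1000 nM to 100000 nM.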

Compound 4, half-maximal effective concentration: > 100000 nM
Compound 4: only a limit was reported; the forecaster's own chance of this, stated with the estimate: 45%; middle value at least 5.0-fold (0.69 log units) from the limit.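

Compound 2 and compound 4 both end at a limit rather than a number, so no step can be read between them: the limit of > 100000 nM in this assay, at which 3 of the 4 values shown sit.

The compounds shown leave open how pyridazin-3-yl and 2-methoxyphenyl on this carbonyl carbon compare when the result is an actual number.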